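The source may hold more compounds than are shown below. What is called first, only, known or untested is meant among the compounds shown, and "the series" means these compounds.

In an ADME assay on HEK293 cells (Homo sapiens) for cytotoxicity, read by ATP content, with a stated time of 6 h (a lower number here means that less compound is tolerated, a higher number that more compound is tolerated), three compounds built on a shared core have been measured so far. Compound 1 `CCC(O)CNc1nc(N)nc2ccn(Cc3ccccn3)c12` gives > 24000 nM, which is a limit and not a number. Compound 2 `CC(Nc1nc(N)nc2ccn(Cc3ccccn3)c12)c1ccccn1` gives > 24000 nM, again a limit. Compound 3 `Cc1cnc(CNc2nc(N)nc3ccn(Cc4ccccn4)c23)o1` gives > 24000 nM, likewise a limit, so it has no exact position on the scale. The series as a whole rests on (the limit of > 24000 nM in this assay, at which 3 of the 3 values shown sit).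

Compound 4 `Cc1cnc(CNc2nc(N)nc3ccn(Cc4ccccn4)c23)s1` carries 5-methyl-1,3-thiazol-2-yl in place of the 5-methyl-1,3-oxazol-2-yl of compound 3, on a saturated chain carbon bound to a nitrogen on an aromatic ring: 5-methyl-1,3-thiazol-2-yl in place of 5-methyl-1,3-oxazol-2-yl on a saturated chain carbon bound to a nitrogen on an aromatic ring.

Three measured changes bear on this exchange: a step that the two limits leave unreadable from compound 1 to compound 2, a step that the two limits leave unreadable from compound 1 to compound 3 and a step that the two limits leave unreadable from compound 2 to compound 3. None has a readable size, yet all three compounds remain at the limit in this assay. No step beyond the scatter and no particular direction is therefore expected, and the estimated step is a step that the limit leaves unreadable from compound 3 to compound 4. Compound 4 is expected at 30000 nM, within an estimated range of 15000 nM to 60000 nM.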

Compound 4, half-maximal cytotoxic concentration: > 24000 nM
Compound 4: no number, only a limit; the forecaster's own chance of this, stated with the estimate: 85%; the middle value lies beyond the limit too.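

Compound 4 gives > 24000 nM in this assay, which is a limit and not a number, so its steps from compound 1, compound 2 and compound 3 cannot be read. The compounds shown leave open whether these exchanges on the shared core change tolerated concentration at all: the limit of > 24000 nM in this assay, at which 4 of the 4 values shown sit.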